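Compound 3: a substituted phenol awaits its number

The source may hold more compounds than are shown below. What is called first, only, known or untested is meant among the compounds shown, and "the series" means these compounds.

Values in a functional assay (Homo sapiens) for inhibition; a higher number here means a weaker inhibitor, a lower number a stronger inhibitor:
- Compound 1 `C[S+]([O-])c1ccc(CCSc2nc(-c3ccc(F)cc3)c(-c3ccncc3)[nH]2)cc1`: 500 nM
- Compound 2 `Oc1ccccc1CSc1nc(-c2ccc(F)cc2)c(-c2ccncc2)[nH]1`: 440 nM
- Compound 3 `CSc1cc(Cl)cc(CSc2nc(-c3ccc(F)cc3)c(-c3ccncc3)[nH]2)c1O`: not yet measured

On these numbers, compound 2 cannot be separated from compound 1, and neither stands apart. The next change is 5-chloro-2-hydroxy-3-(methylsulfanyl)phenyl in place of 2-hydroxyphenyl on a saturated chain carbon bound to a sulfur.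

Going by the values given here, only one measured step bears on this change, and it does so indirectly. The group at this same place was exchanged in a 1.1-fold lower number from compound 1 to compound 2 (0.06 log units; within the scatter), which left the number within the scatter. That step says nothing direct about adding chloro or methylsulfanyl to the phenol ring, so the data offer no measure of either group. Among the compounds with values here, with only this small step as a guide, no shift beyond the scatter is expected in this assay, and the direction remains uncertain. The expected change is a 1.4-fold lower number from compound 2 to compound 3 (0.14 log units; within the scatter). For compound 3, the estimated value is 320 nM, with an estimated range of 90 nM to 1100 nM.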

Compound 3, half-maximal inhibitory concentration: 640 nM
The estimate for compound 3 lay 2.0-fold (0.30 log units) below the measured number; the range from low to high includes it.
By their numbers in this assay, from the lowest: compounds 2, 1 and 3 (each within the scatter of the next).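

In this assay, the step of a 1.5-fold higher number from compound 2 to compound 3 (0.16 log units; within the scatter) shows that the phenol ring at this place, on a saturated chain carbon bound to a sulfur, can carry chloro and methylsulfanyl together without a shift beyond the scatter. The earlier step had exchanged one whole group for another and said nothing about substitution on the 2-hydroxyphenyl ring. With a 1.3-fold higher number from compound 1 to compound 3 (0.11 log units; within the scatter) also lying within the scatter, all three groups seen at this place now give numbers that cannot be told apart, and no measurement at hand offers an account of this flat result.

The compounds shown leave open what chloro and methylsulfanyl each do alone, as the two enter together and their effects could cancel or both be small. They also leave open whether any group at this place can move the number beyond the scatter, for instance a carboxylic acid or an amine on the ring, or a longer chain between the ring and the sulfur.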